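The source may report more compounds than this note shows. Statements on the series, on what has been measured and on what is new or still open speak of the compounds shown alone.

For the measured compounds named here, compound 1 `CCCCCCCCc1cc(O)cc(O)n1` is the only compound here with a measured number: in a functional assay on HEK293 cells for agonist activity at G-protein coupled receptor 84 (Homo sapiens), read by calcium flux (on this read-out higher numbers stand for an effect only at larger amounts of compound and lower numbers for an effect already at smaller amounts), compound 1 gives 1.34 nM. Compound 2 `Nc1cc(O)nc(SCCCCc2ccccc2)n1` returns only a limit of the assay, > 100000 nM, which is the limit of > 100000 nM in this assay, at which 1 of the 2 values shown sits. Compound 3 `CCCCCCCc1cc(O)cc(O)n1` has not yet been measured in this assay. It differs from compound 1 by hydrogen in place of methyl on a saturated chain carbon, seven bonds along the chain from an aromatic carbon. Going by the values given here, with no measured step of this kind available, the change from compound 1 to compound 3 is expected to cost a little potency, a 3.0-fold higher number from compound 1 to compound 3 (0.47 log units; beyond the scatter), beyond the usual scatter. Compound 3 is therefore estimated at 4 nM, between 1.3 nM and 15 nM.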

Compound 3, half-maximal effective concentration: 1.26 nM
For compound 3 the middle estimate is 3.2-fold (0.50 log units) above the measured one; measured number below the stated range.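

Hydrogen in place of methyl on a saturated chain carbon, seven bonds along the chain from an aromatic carbon, gives a 1.1-fold lower number from compound 1 to compound 3 (0.03 log units; within the scatter) in this assay. For the compounds shown here, this is the first measured step at this position, and it shows that this methyl can be lost with no loss of potency that can be told from the scatter. Nothing measured here explains why the two compounds read alike.

Still open, on these data alone, is how a longer chain, or a chain shorter than that of compound 3, would read. So is the effect of an amine or a carboxylic acid in place of this methyl.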